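Sulfonyl series: cytotoxicity limits and compound 4

This account rests on a few compounds, and the source may have more. Where it says the series, first, only, none or still open, it means among the compounds named here.

Measured so far:
Compound 1 `CC1CCN(S(=O)(=O)c2ccc(NC(=O)c3ccc([N+](=O)[O-])o3)cc2)CC1`: in an ADME assay on IMR-90 cells (Homo sapiens) for cytotoxicity, read by CellTiter-Blue, with a stated time of 46 h (on this read-out higher numbers stand for an effect only at larger amounts of compound and lower numbers for an effect already at smaller amounts), compound 1 gives > 25000 nM, which is a limit of the assay and not a number.
Compound 2 `CC(C)(C)C1CCN(S(=O)(=O)c2ccc(NC(=O)c3ccc([N+](=O)[O-])o3)cc2)CC1`: in this assay compound 2 gives > 25000 nM, again a limit of the assay.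
Compound 3 `O=C(Nc1ccc(S(=O)(=O)C2CCCCC2)cc1)c1ccc([N+](=O)[O-])o1`: in this assay compound 3 gives > 25000 nM, also a limit of the assay.

Compound 3 therefore stands only at a limit, and the other two values are limits as well; all three sit at the limit of > 25000 nM in this assay, at which 3 of the 3 values shown sit. The steps a step that the two limits leave unreadable from compound 1 to compound 2, a step that the two limits leave unreadable from compound 1 to compound 3 and a step that the two limits leave unreadable from compound 2 to compound 3 are accordingly unreadable in size and direction.

Compound 4 `O=C(Nc1ccc(S(=O)(=O)C2=CCOC=C2)cc1)c1ccc([N+](=O)[O-])o1` differs from compound 3 by a group of 6 heavy atoms (5 carbon, 1 oxygen; one six-membered non-aromatic ring with 1 hetero atom) in place of a group of 6 heavy atoms (6 carbon; one six-membered non-aromatic ring of carbon only), on a sulfonyl sulfur. The steps that touch the same place, the exchanges on the sulfonyl sulfur from compound 1 to compound 3 and from compound 2 to compound 3, were both left unreadable by the limits, so no step beyond the scatter can be read from them. For compound 4 the expectation is an outcome at the same limit rather than a number, with an expected step that the limit leaves unreadable from compound 3 to compound 4. Compound 4 is estimated at 30000 nM in this assay, with a range from 10000 nM to 100000 nM.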

Compound 4, half-maximal effective concentration: > 25000 nM
Compound 4 was reported as a limit; the forecaster's own chance of this, stated with the estimate: 80%; the middle value does not contradict the limit.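

In this assay the steps from compound 1, compound 2 and compound 3 to compound 4 cannot be read, as all four compounds stand at a limit and not at a number: the limit of > 25000 nM in this assay, at which 4 of the 4 values shown sit.

The compounds shown leave open whether the groups on the sulfonyl sulfur differ at all on this read-out.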